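The compounds below may be only part of what the source reports. "The series", "measured", "known", "first", "only" and "open" are said of these compounds alone.

Among the measured compounds shown here, in a functional assay on MOLT-4 cells (Homo sapiens) for antiproliferative activity (on this read-out higher numbers stand for weaker inhibition and lower numbers for stronger inhibition), compound 2 (`COc1cccc(-c2cc(N)c(C(=O)c3cc(OC)c(OC)c(OC)c3)s2)c1`) gives 17 nM, the lower of the two numbers measured so far, while compound 1 (`COc1cc(C(=O)c2sc(-c3ccc(Cl)cc3)cc2N)cc(OC)c1OC`) gives 77 nM. Compound 3 (`CCOc1ccc(-c2cc(N)c(C(=O)c3cc(OC)c(OC)c(OC)c3)s2)cc1`) keeps the core of compound 2 and changes only the aryl group on an aromatic carbon next to the ring sulfur, with 4-ethoxyphenyl in place of 3-methoxyphenyl on an aromatic carbon. For the measured compounds named here, only one measured step bears on this place, a 4.5-fold lower number from compound 1 to compound 2 (0.66 log units; beyond the scatter), a modest change on swapping 4-chlorophenyl for 3-methoxyphenyl. Going by these compounds, it shows that a swap here can move the number beyond the scatter, but neither measured compound carries 4-ethoxyphenyl, so the direction remains open and the range stays wide. The expected step is a 1.3-fold higher number from compound 2 to compound 3 (0.11 log units; within the scatter), which means no change beyond the scatter is expected in this assay. For compound 3 the estimated value is 22 nM, within an expected range of 6 nM to 80 nM.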

Compound 3, half-maximal inhibitory concentration: 240 nM
Estimate against measurement, compound 3: 11-fold (1.04 log units) below, outside the stated range (above it).
By their numbers in this assay, from the lowest: compound 2; then compound 1; then compound 3.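

In this assay, the aryl group on this aromatic carbon matters far more than the earlier pair suggested: 4-ethoxyphenyl in place of 3-methoxyphenyl gives a 14-fold higher number from compound 2 to compound 3 (1.15 log units; beyond the scatter), a large step where the earlier one was modest. Compound 3 also falls behind the chloro compound, with ethoxy in place of chloro giving a 3.1-fold higher number from compound 1 to compound 3 (0.49 log units; beyond the scatter), so it has the highest number of the three, with its steps to both others beyond the scatter. No measurement at hand accounts for this loss.

The step from 3-methoxyphenyl to 4-ethoxyphenyl alters both the chain and where it sits on the phenyl ring, so the compounds shown do not separate these two changes. 3-Ethoxyphenyl and 4-methoxyphenyl would bear on that, and how an amine on the phenyl ring would read remains open.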